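The source may report more compounds than this note shows. Statements on the series, on what has been measured and on what is new or still open speak of the compounds shown alone.

Within the data shown here, in an ADME assay on microsomes from liver (Homo sapiens) for metabolic stability (a lower number here means that the compound disappears faster, a higher number that the compound lasts longer), compound 1 `O=C(O)c1ccc(N2CCC3(C=C(c4c(-c5c(Cl)cccc5Cl)noc4C4CC4)C3)CC2)nc1` gives 0.667 h and stands second highest of the three numbers measured so far. Compound 3 `O=C(O)c1cc(F)c2nc(N3CCC(CCc4c(-c5c(Cl)cccc5Cl)noc4C4CC4)CC3)sc2c1` gives 0.317 h and is the nearest to compound 1, lying lower by a gap beyond the scatter. Compound 2 `O=C(O)c1ccc2cc(N3CCC4(C=C(c5c(-c6c(Cl)cc(F)cc6Cl)noc5C5CC5)C4)CC3)ccc2n1` gives 1.67 h and lies higher than compound 1, also beyond the scatter.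

Compound 4 `O=C(O)c1ccc(N2CCC3(C=C(c4c(-c5c(Cl)cccc5Cl)noc4C4CC4)C3)CC2)cn1` has not yet been measured. It holds the same atoms as compound 1, joined differently, with 6-carboxypyridin-3-yl in place of 5-carboxypyridin-2-yl on an amine nitrogen in a ring as the counted difference: 6-carboxypyridin-3-yl in place of 5-carboxypyridin-2-yl on an amine nitrogen in a ring. Among the measured compounds shown here, no measured pair shows this change on its own, so the expectation rests on compound 1 at 0.667 h as its anchor. In this assay the expected 1.1-fold higher number from compound 1 to compound 4 (0.05 log units; within the scatter) is a small upward move that stays within the scatter. For compound 4 the estimated half-life is 0.75 h with an expected range from 0.33 h to 1.6 h for a single measurement.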

Compound 4, half-life: 1.25 h
Beside the measured number, compound 4's estimate is 1.7-fold (0.22 log units) below it, and the stated range covers the measured number.
By their numbers in this assay, from the lowest: compound 3; then compounds 1, 4 and 2 (each within the scatter of the next, the first and the last beyond it).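

In this assay the exchange of 5-carboxypyridin-2-yl for 6-carboxypyridin-3-yl on an amine nitrogen in a ring gives a 1.9-fold higher number from compound 1 to compound 4 (0.27 log units; within the scatter), the first step among the compounds shown that alters one place alone. On the core of compound 1, these two groups, which hold the same atoms joined differently, therefore cannot be told apart in this read-out, since the step stays within the usual scatter. Nothing available bears on what lies behind this step.

The compounds shown leave open whether a carboxylic acid on a phenyl ring, or a primary amide in place of the carboxylic acid, on the same amine nitrogen would also stay within the scatter of compound 1. They also leave open whether this exchange would give a similar step on a core other than that of compound 1.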